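Removing a Ring Hydroxy from a Nucleoside-like Adenine Derivative

The compounds below may be only part of what the source reports. "The series", "measured", "known", "first", "only" and "open" are said of these compounds alone.

Measured compounds:
compound 1 `Nc1ncnc2c1ncn2[C@H]1C[C@H](CO)CO1`, 7%
compound 2 `Nc1ncnc2c1ncn2[C@@H]1OC[C@@](O)(CO)[C@H]1O`, 10%
compound 3 `Nc1ncnc2c1ncn2[C@@H]1OC[C@H](CO)[C@H]1O`, 32%

In an assay on CHO cells for displacement of a labelled ligand from adenosine receptor A3 (Homo sapiens), tested at 10 uM (a higher number here means more inhibition at the concentration tested (going by the name of the read-out), a lower number less inhibition), compound 3 gives 32%, the highest of the three numbers, with compound 2 and compound 1 both beyond the scatter below it. Compound 4 `Nc1ncnc2c1ncn2[C@H]1C[C@@H](CO)CO1` is not yet measured. It differs from compound 3 by hydrogen in place of hydroxy on a saturated ring carbon. Going by the values given here, one measured step bears on this change: a number 22 percentage points higher from compound 2 to compound 3 (beyond the scatter), the same kind of change. Taken alone, that step suggests a rise. Compound 1, which also has no hydroxy on its ring, gives only 7%, so the rise is uncertain. The expected step of a number 2 percentage points lower from compound 3 to compound 4 (within the scatter) is small or none beyond the scatter. Compound 4 is estimated at 30%, within 8% to 55%.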

Compound 4, a percentage reported as inhibition, at one concentration (the size of the read-out at that concentration, not a potency): 31%
The estimate for compound 4 lay 1 percentage points below the measured number; the range from low to high includes it.
By their numbers in this assay, from the lowest: compounds 1 and 2 (each within the scatter of the next); then compounds 4 and 3 (each within the scatter of the next).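

In this assay, the swap of hydroxy for hydrogen on this saturated ring carbon does not repeat its earlier rise: a number 1 percentage points lower from compound 3 to compound 4 (within the scatter). The drawn configuration separates the two ring forms without this hydroxy, with a number 24 percentage points higher from compound 1 to compound 4 (beyond the scatter). The low number of compound 1 therefore says nothing against losing the hydroxy, because the gap to compound 4 lies in configuration alone: the fact that compounds 1 and 4 differ only in the configuration as drawn

Open, as far as these compounds go, is whether an amine or a methoxy group on this ring carbon would keep the number of compound 4. Also open, from the compounds shown here alone, is what inverting the other stereocentre would do.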